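The source may report more compounds than this note shows. Statements on the series, on what has been measured and on what is new or still open speak of the compounds shown alone.

Going by the values given here, compound 3 `CCCC1(c2ccccc2)NC(=O)N(Cc2ccc(C(=O)NO)cc2)C1=O` gives 50.9 nM in an assay on isolated protein for inhibition of protein deacetylase HDAC6 (Homo sapiens), read by fluorescence, with stated times of 10 min and 2 h (on this read-out higher numbers stand for weaker inhibition and lower numbers for stronger inhibition), the highest of the three numbers measured so far; compound 2 `CC(C)(C)c1ccc(CN2CC(=O)N(Cc3ccc(C(=O)NO)cc3)C2=O)cc1` gives 40.7 nM, a gap within the scatter, while compound 1 `O=C(NO)c1ccc(CN2C(=O)CN(Cc3ccc(Cl)cc3)C2=O)cc1` gives 8.3 nM, a gap beyond it. Among the compounds with values here, the one single-point step measured, a 4.9-fold higher number from compound 1 to compound 2 (0.69 log units; beyond the scatter), concerns a substituent on an aromatic carbon and is not of the kind now in question.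

Compound 4 `O=C(NO)c1ccc(CN2C(=O)NC(CCc3ccccc3)(c3ccccc3)C2=O)cc1` differs from compound 3 by phenyl in place of methyl on a saturated chain carbon, two bonds along the chain from a saturated ring carbon. Within the data shown here, no measured pair in this assay isolates a change of this type on the saturated chain, so the expectation rests on the general spread of the series, whose numbers lie close to one another, rather than on a matching step. Compound 4 is therefore expected to show a step of a 1.0-fold lower number from compound 3 to compound 4 (0.01 log units; within the scatter), that is, no change beyond the scatter. The estimate for compound 4 in this assay is 50 nM, with a range from 20 nM to 130 nM.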

Compound 4, half-maximal inhibitory concentration: 24.7 nM
Compound 4: the middle estimate sits 2.0-fold (0.31 log units) above what was measured, within the range that was stated.
By their numbers in this assay, from the lowest: compound 1; then compounds 4, 2 and 3 (each within the scatter of the next, the first and the last beyond it).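

The propyl to phenethyl change, phenyl in place of methyl on a saturated chain carbon, two bonds along the chain from a saturated ring carbon, gives a 2.1-fold lower number from compound 3 to compound 4 (0.31 log units; beyond the scatter) in this assay, so this position accepts an added aromatic ring with a modest gain in inhibition. Going by these compounds alone, this is the first measured step on the saturated chain; the earlier step, a 4.9-fold higher number from compound 1 to compound 2 (0.69 log units; beyond the scatter), concerns a substituent on an aromatic carbon and says nothing about this position. No available evidence accounts for the direction or size of the new step.

Going by these compounds, whether the step follows from the aromatic ring or from the added length alone remains open, and a longer chain such as pentyl in place of propyl would separate the two. Also open, on these data alone, is whether a chain ending in an amine or a carboxylic acid would fare as well as phenethyl.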